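From cyclopropyl to 1H-imidazol-1-yl: an expected fall

A few compounds are considered here, and "the series" means these few. Any claim that something is new, unique, unknown or untested is made for them only; others in the source may bear on it.

Among the compounds with values here, in a physicochemical assay for lipophilicity, using the shake flask method (a lower number here means a more polar compound, a higher number a more lipophilic compound), compound 2 (`C[C@H](Oc1ccc2ncc(/C=C/C(=O)O)c(C3CC3)c2c1)c1c(Cl)ccc(F)c1Cl`) gives 4.1 as the higher of the two numbers so far, while compound 1 (`C[C@H](Oc1ccc2ncc(/C=C/C(=O)O)c(C(F)F)c2c1)c1c(Cl)ccc(F)c1Cl`) gives 3.1 on the same scale. Compound 3 (`C[C@H](Oc1ccc2ncc(/C=C/C(=O)O)c(-n3ccnc3)c2c1)c1c(Cl)ccc(F)c1Cl`) carries 1H-imidazol-1-yl in place of cyclopropyl on an aromatic carbon, opposite the ring nitrogen (1H-imidazol-1-yl in place of cyclopropyl on an aromatic carbon). Within the data shown here, only one measured step bears on this change, and it is a different swap in the same place, cyclopropyl in place of difluoromethyl. Taking a number 1.00 log units higher from compound 1 to compound 2 (beyond the scatter) as the guide for size, and with hydrogen-bond acceptors entering where the leaving group has none, a fall of similar size is expected, though no measurement yet tests this swap. The estimate is a number 1.10 log units lower from compound 2 to compound 3 (beyond the scatter) as the expected step. For compound 3 the estimated value is 3 with an expected range of 2.3 to 3.7 in this assay once it is measured.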

Compound 3, distribution coefficient: 2
The estimate for compound 3 lay 1.00 log units above the measured number; the measured number lies below the stated range.
By their numbers in this assay, from the lowest: compound 3; then compound 1; then compound 2.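

In this assay, this position opposite the ring nitrogen proves more sensitive to its substituent than the first pair could show, with 1H-imidazol-1-yl giving a number 2.10 log units lower from compound 2 to compound 3 (beyond the scatter) and also a number 1.10 log units lower from compound 1 to compound 3 (beyond the scatter) when it replaces difluoromethyl. Compound 3 therefore has the lowest number of the three, and a single change on this aromatic carbon spans more than the step between compound 1 and compound 2 had revealed. No supporting measurement is available to explain why the fall is this large.

The compounds shown do not separate the contribution of the two nitrogens in 1H-imidazol-1-yl from that of its five-membered aromatic ring. A phenyl ring on the same carbon could help to tell these apart, while a methoxy group or an amine would show how other groups fit within this range.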